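Swapping the Dichlorophenyl for a Methoxyphenyl on an Inactive Amide

A few compounds are considered here, and "the series" means these few. Any claim that something is new, unique, unknown or untested is made for them only; others in the source may bear on it.

Compound 1 `C=CC1=C(C(=O)NCCC)C(c2ccc(Cl)c(Cl)c2)OC1` in a functional assay on A549 cells (Homo sapiens) for cytotoxicity, read by MTT assay, with a stated time of 24 h; on this read-out lower numbers stand for stronger inhibition and higher numbers for weaker inhibition: > 100000 nM, a limit of the assay.
Compound 2 `C=CC1=C(C(=O)Nc2ccccc2OC)C(c2ccc(Cl)c(Cl)c2)OC1` in this assay : > 100000 nM, a limit of the assay.

Among the measured compounds shown here, compound 2 stands at the limit of this assay, and the limit of > 100000 nM in this assay, at which 2 of the 2 values shown sit, shows that both values so far sit there. For the measured compounds named here, the only measured step, a step that the two limits leave unreadable from compound 1 to compound 2, therefore cannot be read in size or direction, and it concerns the amide-type nitrogen, not the saturated ring carbon. Compound 3 `C=CC1=C(C(=O)Nc2ccccc2OC)C(c2ccc(OC)cc2)OC1` differs from compound 2 by 4-methoxyphenyl in place of 3,4-dichlorophenyl on a saturated ring carbon. Going by the values given here, no measured step bears on this change, so nothing in the data points to a move in either direction. Compound 3 is thus expected to remain at the limit, with a number no higher from compound 2 to compound 3 (the limit leaves the size open) as the estimated step. The estimate for compound 3 is 100000 nM, with a range from 30000 nM to 300000 nM, and most likely only a limit will be reported again.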

Compound 3, half-maximal inhibitory concentration: > 100000 nM
Compound 3: no number, only a limit; the forecaster's own chance of this, stated with the estimate: 80%; the middle value lies on the limit itself.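

Among the compounds shown here, compound 2 and compound 3 both give only a limit in this assay, so no step between them can be read in size or direction: the limit of > 100000 nM in this assay, at which 3 of the 3 values shown sit. The compounds shown leave open whether changing the group on the amide-type nitrogen or on the saturated ring carbon alters cytotoxicity at all.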